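This account rests on a few compounds, and the source may have more. Where it says the series, first, only, none or still open, it means among the compounds named here.

- Compound 1 `COc1ccc(-n2c(SCc3ccccc3)nnc2-c2cc(OC)c(OC)c(OC)c2)cc1`: > 60000 nM, a limit of the assay
- Compound 2 `COc1ccc(-n2c(SCC(=O)c3ccc(F)cc3)nnc2-c2cc(OC)c(OC)c(OC)c2)cc1`: 42500 nM
- Compound 3 `COc1ccc(-n2c(SCC(=O)c3ccc(OC)c(O)c3)nnc2-c2cc(OC)c(OC)c(OC)c2)cc1`: > 60000 nM, a limit of the assay

In a functional assay on HT-29 cells (Homo sapiens) for inhibition, read by MTT assay, with a stated time of 48 h (a lower number here means a stronger inhibitor, a higher number a weaker inhibitor), compound 3 gives > 60000 nM, which is a limit and not a number. It stands at the limit of > 60000 nM in this assay, at which 2 of the 3 values shown sit.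

Compound 4 `COc1ccc(NC(=O)CSc2nnc(-c3cc(OC)c(OC)c(OC)c3)n2-c2ccc(OC)cc2)cc1` differs from compound 3 as follows: (4-methoxyphenyl)amino in place of 3-hydroxy-4-methoxyphenyl on a carbonyl carbon. In words, (4-methoxyphenyl)amino replaces 3-hydroxy-4-methoxyphenyl on a carbonyl carbon, so (3-hydroxy-4-methoxyphenyl)carbonyl becomes (4-methoxyphenyl)carbamoyl.

The closest measured change sits on the same carbonyl carbon, and it gave an at least 1.4-fold higher number from compound 2 to compound 3 (0.14 log units; that floor lies within the scatter). The change on the saturated chain carbon bound to a sulfur gave an at least 1.4-fold lower number from compound 1 to compound 2 (0.14 log units; that floor lies within the scatter). The related change gave a step that the two limits leave unreadable from compound 1 to compound 3.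

Among the compounds with values here, with compound 2 at 42500 nM as the only true number, no step beyond the scatter is expected in this assay. Compound 4 may well return only a limit. The expected change is an at least 1.2-fold lower number from compound 3 to compound 4 (0.07 log units; that floor lies within the scatter). The estimated value for compound 4 is 50000 nM, with an expected range from 15000 nM to 90000 nM.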

Compound 4, half-maximal inhibitory concentration: 45300 nM
The estimate for compound 4 lay 1.1-fold (0.04 log units) above the measured number; the measured number falls inside the stated range.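

In this assay, the new group on the carbonyl carbon gives a second true number, and it cannot be told apart from the 4-fluorophenyl group at this place: a 1.1-fold higher number from compound 2 to compound 4 (0.03 log units; within the scatter). Compound 1 and compound 3 each stand only at a limit, so the steps to compound 4 are floors, an at least 1.3-fold lower number from compound 3 to compound 4 (0.12 log units; that floor lies within the scatter) and an at least 1.3-fold lower number from compound 1 to compound 4 (0.12 log units; that floor lies within the scatter), and a real gain is neither shown nor ruled out. The carbonyl carbon therefore accepts a (4-methoxyphenyl)amino group and still gives a true number, but no compound yet separates clearly from the limit: the limit of > 60000 nM in this assay, at which 2 of the 4 values shown sit.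

Going by these compounds, whether any replacement here can move the number well beyond the scatter stays open. A carboxylic acid or a simple amine on the carbonyl carbon, or a longer chain on the sulfur, could test this.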